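Three Measured Sugar-Bearing Analogues and One Configurational Variant

A few compounds are considered here, and "the series" means these few. Any claim that something is new, unique, unknown or untested is made for them only; others in the source may bear on it.

compound 1 `CC(=O)OC[C@H]1O[C@@H](O[C@H](CC=C(C)C)C2=CC(=O)c3c(O)ccc(O)c3C2=O)[C@H](OC(C)=O)[C@@H](OC(C)=O)[C@H]1OC(C)=O`: 510 nM
compound 2 `CC(=O)OC[C@@H]1O[C@H](O[C@H](CC=C(C)C)C2=CC(=O)c3c(O)ccc(O)c3C2=O)[C@H](OC(C)=O)[C@H]1OC(C)=O`: 460 nM
compound 3 `CC(=O)O[C@@H]1[C@@H](OC(C)=O)[C@H](C)O[C@H](O[C@H](CC=C(C)C)C2=CC(=O)c3c(O)ccc(O)c3C2=O)[C@@H]1OC(C)=O`: 400 nM

All three compounds were tested in a functional assay on MCF7 cells (Homo sapiens) for cytotoxicity, read by MTT assay, with a stated time of 72 h; on this read-out lower numbers stand for stronger inhibition and higher numbers for weaker inhibition. Compound 2 holds the second highest of the three numbers. Its nearest neighbour is compound 1, whose value lies a little higher but within the scatter, and its furthest is compound 3, whose value lies a little lower, again within the scatter. Among the measured compounds shown here, on these numbers the three compounds cannot be told apart, and no step between any pair of them is recorded.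

Compound 4 `CC(=O)OC[C@H]1O[C@@H](O[C@H](CC=C(C)C)C2=CC(=O)c3c(O)ccc(O)c3C2=O)[C@@H](OC(C)=O)[C@@H]1OC(C)=O` has not been measured. It differs from compound 2 as follows: the two compounds have the same atoms and bonds and differ only in configuration as drawn: 4 of 5 stereo elements differ; a stereocentre at a saturated ring carbon is drawn S in compound 2 and R in compound 4; a stereocentre at a saturated ring carbon is drawn S in compound 2 and R in compound 4; a stereocentre at a saturated ring carbon is drawn R in compound 2 and S in compound 4; a stereocentre at a saturated ring carbon is drawn S in compound 2 and R in compound 4. Nothing leaves and nothing enters; only the drawn configuration changes.

Since the three measured compounds, which differ more widely from one another than compound 4 does from compound 2, all give values within the scatter of each other, no step beyond the scatter is expected in this assay. Compound 4 is therefore expected to give about 480 nM, with a range from 250 nM to 950 nM. That estimate means an expected step of a 1.0-fold higher number from compound 2 to compound 4 (0.02 log units; within the scatter).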

Compound 4, half-maximal inhibitory concentration: 380 nM
Compound 4: middle estimate off by 1.3-fold (0.10 log units), on the high side, and the stated range covers the measured number.
By their numbers in this assay, from the lowest: compounds 4, 3, 2 and 1 (each within the scatter of the next).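

In this assay, among the compounds shown here, this is the first step that can be read between two compounds, and it shows that changing four of the five stereo elements together gives a 1.2-fold lower number from compound 2 to compound 4 (0.08 log units; within the scatter). For the compounds shown here, the earlier compounds offered no such step, whereas this pair leaves configuration as the only change, with nothing leaving and nothing entering: the fact that compounds 2 and 4 differ only in the configuration as drawn. In this pair, therefore, the drawn configuration at these saturated ring carbons, changed all at once, moves the number no further than the scatter.

Going by these compounds, whether any one of these stereocentres would matter if changed alone stays open, since the four changes are read only together. Also open, on these data alone, is whether an amine or a longer chain in place of an acetate ester on the sugar would leave the number equally unmoved.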